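A few compounds are considered here, and "the series" means these few. Any claim that something is new, unique, unknown or untested is made for them only; others in the source may bear on it.

The compounds here were tested in an ADME assay on THP-1 cells (Homo sapiens) for cytotoxicity; on this read-out higher numbers stand for lower toxicity in this test and lower numbers for higher toxicity in this test. Compound 1 `Clc1ccc2nc(-c3ccccn3)c(Nc3ccc4c(c3)OCCO4)n2c1` gives > 50000 nM, which is a limit of the assay and not a number. Compound 2 `Cc1ccc2nc(-c3ccc(N(C)C)cc3)c(NC3CCCCC3)n2c1` gives > 50000 nM, again only a limit. Compound 3 `CN(C)CCNc1c(-c2ccccn2)nc2ccccn12` gives > 50000 nM, also a limit. Compound 3 therefore has no exact number to start from, and it shares with compound 1 and compound 2 (the limit of > 50000 nM in this assay, at which 3 of the 3 values shown sit). Going by the values given here, no measured pair yet shows what a single change does in this assay.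

Compound 4 `c1ccc(-c2nc3ccccn3c2NC2CCOC2)nc1` keeps the core of compound 3 but carries oxolan-3-yl in place of 2-(dimethylamino)ethyl on a nitrogen on an aromatic ring. Given how alike the three measured results are, the expected step, a number no higher from compound 3 to compound 4 (the limit leaves the size open), is none beyond the usual scatter, in either direction. Compound 4 is estimated at 50000 nM, with an expected range from 25000 nM to 100000 nM, and the assay may well report only a limit again.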

Compound 4, half-maximal cytotoxic concentration: > 50000 nM
Compound 4 gave a limit, no number; the forecaster's own chance of this, stated with the estimate: 85%; the middle value sits exactly at the limit.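

No step can be read from compound 3 to compound 4, because both results are only limits of the assay: the limit of > 50000 nM in this assay, at which 4 of the 4 values shown sit.

The compounds shown leave open how far each lies beyond that limit, and which structural change, if any, would give a measurable cytotoxic concentration.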